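The compounds below may be only part of what the source reports. "The series", "measured", "known", "first", "only" and "open" are said of these compounds alone.

In an ADME assay on Vero cells (Chlorocebus sabaeus) for cytotoxicity, with a stated time of 7 days (on this read-out lower numbers stand for higher toxicity in this test and higher numbers for lower toxicity in this test), compound 2 `COc1ccc2[nH]c(C(=O)N3CC(=O)N(Cc4ccccc4)[C@@H](N4CCc5ccccc54)C3)cc2c1` gives > 100000 nM, which is a limit of the assay rather than a number. For the measured compounds named here, compound 1 `COc1ccc2[nH]c(C(=O)N3CC(=O)N(Cc4ccccc4)[C@@H](COCc4ccccc4)C3)cc2c1` is the only other compound measured here, and in this assay compound 1 gives > 30000 nM, again a limit. The step that the two limits leave unreadable from compound 1 to compound 2 therefore cannot be read as a size, since one value sits at the limit of > 100000 nM in this assay, at which 1 of the 2 values shown sits, and the other at the limit of > 30000 nM in this assay, at which 1 of the 2 values shown sits. Compound 3 `COc1ccc2[nH]c(C(=O)N3CC(=O)N(Cc4ccccc4)[C@@H](COc4ccc(F)cc4)C3)cc2c1` has not yet been measured in this assay. It differs from compound 2 in one place: (4-fluorophenoxy)methyl in place of 2,3-dihydro-1H-indol-1-yl on a saturated ring carbon. Going by the values given here, no measured step separates two actual numbers, so there is nothing that shows this kind of change moving the read-out beyond the scatter in either direction. The expectation is that compound 3 behaves much like compound 2, with a step of an at least 1.6-fold lower number from compound 2 to compound 3 (0.22 log units; that floor lies within the scatter) that most likely cannot be read at all. Compound 3 is estimated at 60000 nM, within the range 20000 nM to 200000 nM.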

Compound 3, half-maximal cytotoxic concentration: 33200 nM
For compound 3 the middle estimate is 1.8-fold (0.26 log units) above the measured one, and the stated range covers the measured number.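

In this assay, for the compounds shown here, the change on a saturated ring carbon from 2,3-dihydro-1H-indol-1-yl to (4-fluorophenoxy)methyl gives an at least 3.0-fold lower number from compound 2 to compound 3 (0.47 log units; beyond the scatter), the first readable step at this position. A lower number means higher toxicity in this test, so a change here can move the read-out beyond the scatter, and the true step may be larger, as compound 2 gives only a limit. Compound 1 also gives a limit and not a number, so its comparison with compound 3 cannot be read: the limit of > 30000 nM in this assay, at which 1 of the 3 values shown sits.

Going by these compounds, it remains open whether the step goes with the loss of 2,3-dihydro-1H-indol-1-yl or the arrival of (4-fluorophenoxy)methyl. Also open, on these data alone, is how a phenoxymethyl group without the fluorine, or a simple amine such as dimethylamino, would read on this carbon.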